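The source may hold more compounds than are shown below. What is called first, only, known or untested is meant among the compounds shown, and "the series" means these compounds.

In an assay on CHO cells for displacement of a labelled ligand from adenosine receptor A1 (Homo sapiens), read by scintillation counting, with a stated time of 90 min, tested at 1 uM, in the presence of a further agent that is not named here (on this read-out lower numbers stand for less inhibition and higher numbers for more inhibition at the one concentration tested (going by the name of the read-out)), compound 2 `CCCn1c(=O)[nH]c2nc(-c3ccc(S(=O)(=O)N4CCN(c5ccccc5F)CC4)cc3)[nH]c2c1=O` gives 13%. For the measured compounds named here, the only other measured compound, compound 1 `CCCn1c(=O)[nH]c2nc(-c3ccc(S(=O)(=O)N4CCN(c5ccc(Cl)cc5F)CC4)cc3)[nH]c2c1=O`, gives 9% in this assay. Compound 2 carries the larger of the two numbers, but the step of a number 4 percentage points higher from compound 1 to compound 2 (within the scatter) lies within the scatter, so the two are not truly separated. Compound 3 `CCCn1c(=O)[nH]c2nc(-c3ccc(S(=O)(=O)N4CCN(c5cccc(F)c5)CC4)cc3)[nH]c2c1=O` differs from compound 2 by 3-fluorophenyl in place of 2-fluorophenyl on an amine nitrogen in a ring. Going by the values given here, no measured step moves the fluorine around its ring; the one step available, chloro to hydrogen, changed little. The number for compound 3 is therefore expected near that of compound 2, a step of no change at the digits printed from compound 2 to compound 3 (within the scatter). The estimate for compound 3 is 13%, expected between 3% and 28%.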

Compound 3, a percentage reported as inhibition, at one concentration (the size of the read-out at that concentration, not a potency): 34%
Beside the measured number, compound 3's estimate is 21 percentage points below it; the whole stated range lies below it.
By their numbers in this assay, from the lowest: compounds 1 and 2 (each within the scatter of the next); then compound 3.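

In this assay, moving the fluorine within the group on the ring nitrogen gives a number 21 percentage points higher from compound 2 to compound 3 (beyond the scatter) even though the atoms stay the same, so this position responds to a change that the earlier chloro-to-hydrogen step did not reveal. Replacing 4-chloro-2-fluorophenyl with 3-fluorophenyl gives a number 25 percentage points higher from compound 1 to compound 3 (beyond the scatter) and leads to the same compound with the higher number. Nothing available explains why the location of the fluorine matters.
As far as these compounds go, it remains open how 4-fluorophenyl would compare, and whether a methoxy group or an amine at the place of the fluorine in 3-fluorophenyl would keep this gain.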